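A few compounds are considered here, and "the series" means these few. Any claim that something is new, unique, unknown or untested is made for them only; others in the source may bear on it.

Measured so far:
- compound 1, `COc1cccc([C@@H](CO)O[C@H]2CCCN(Cc3ccc(C(=O)O)cc3C)[C@H]2c2ccccc2)c1`: 81000 nM
- compound 2, `OC[C@@H](O[C@H]1CCCN(Cc2nc3ccccc3[nH]2)[C@H]1c1ccccc1)c1cc(Cl)cc(Cl)c1`: 4700 nM

Compound 1 carries the highest number of the two in an assay on isolated protein for activation of cGMP-dependent protein kinase 1 (Homo sapiens), read by ADP-Glo, with stated times of 30 min and 2 h, in the presence of a further agent that is not named here; a higher number here means that more compound is needed for the effect, a lower number that less compound is needed. In this assay compound 2 gives 4700 nM, a lower number than compound 1 gives, and the gap lies beyond the scatter. For the measured compounds named here, no single-place step connects compound 1 and compound 2; they differ in more than one place, so the two values show only that the pair sits far apart.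

Compound 3, `Cc1cc(C(=O)O)ccc1CN1CCC[C@H](OC(c2cc(Cl)cc(Cl)c2)C(C)O)[C@@H]1c1ccccc1`, has not yet been measured. It differs from compound 1 by a group of 12 heavy atoms (9 carbon, 1 oxygen, 2 chlorine; one six-membered aromatic ring of carbon only) in place of a group of 11 heavy atoms (9 carbon, 2 oxygen; one six-membered aromatic ring of carbon only), on an oxygen on a saturated carbon. The entering group shares its dichlorinated aromatic ring with compound 2, whose value is the lower of the two, but compound 2 also bears a different group on the ring nitrogen, so the direction of the step is not fixed by any measured pair. A lower number than compound 1 is expected, with the step from compound 1 to compound 3 estimated at a 4.1-fold lower number from compound 1 to compound 3 (0.61 log units; beyond the scatter). For compound 3 the expected value is 20000 nM, within a range of 5000 nM to 80000 nM.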

Compound 3, half-maximal effective concentration: 5300 nM
Estimate against measurement, compound 3: 3.8-fold (0.58 log units) above, and the stated range covers the measured number.
By their numbers in this assay, from the lowest: compounds 2 and 3 (each within the scatter of the next); then compound 1.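

In this assay the change at the group on an oxygen on a saturated carbon gives a large step (a 15-fold lower number from compound 1 to compound 3 (1.18 log units; beyond the scatter)), so this position is sensitive to the exchange while the rest of compound 1 stays fixed. The exchange is not a single feature: a group of 11 heavy atoms with 2 oxygen and 1 defined stereocentre gives way to a group of 12 heavy atoms with 1 oxygen and 2 chlorine and no defined stereocentre. No measurement at hand accounts for the size of the step.

Which part of the exchange carries the step stays open, since the chain and the ring substituents change together. Also open, as far as these compounds go, is how a single chlorine or a trifluoromethyl group on the aromatic ring would read at this position.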